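Chloro for fluoro in a urea series tested on aorta

The source may report more compounds than this note shows. Statements on the series, on what has been measured and on what is new or still open speak of the compounds shown alone.

Compound 1 `COc1cccc(NC(=O)NC2CC(C)(C)Oc3ccc(F)cc32)c1`, compound 2 `COc1cccc(NC(=O)NC2CC(C)(C)Oc3ccc(Cl)cc32)c1` and compound 3 `Cc1ccc(NC(=O)NC2CC(C)(C)Oc3ccc(F)cc32)cc1` share one urea core. In a functional assay (aorta) with Rattus norvegicus as the target (a higher number here means that more compound is needed for the effect, a lower number that less compound is needed), compound 1 gives only a limit of the assay, > 10000 nM. Compound 2 likewise gives only a limit, > 10000 nM. Compound 3 too gives only a limit, > 30000 nM. The change chloro in place of fluoro on an aromatic carbon thus yields a step that the two limits leave unreadable from compound 1 to compound 2. The cores of compound 1 and compound 3 differ by 4-methylphenyl in place of 3-methoxyphenyl on an amide-type nitrogen, giving a step that the two limits leave unreadable from compound 1 to compound 3. Compound 4 `Cc1ccc(NC(=O)NC2CC(C)(C)Oc3ccc(Cl)cc32)cc1` has not been measured; it differs from compound 3 by chloro in place of fluoro on an aromatic carbon, the same change as that between compound 1 and compound 2. Because the limit of > 10000 nM in this assay, at which 2 of the 3 values shown sit, and the limit of > 30000 nM in this assay, at which 1 of the 3 values shown sits, are all the measured compounds show, a step that the limit leaves unreadable from compound 3 to compound 4 is expected. Compound 4 is expected to give about 50000 nM in this assay, most probably again only as a limit.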

Compound 4, half-maximal effective concentration: > 30000 nM
Compound 4 ended at the assay's limit; the forecaster's own chance of this, stated with the estimate: 85%; the middle value does not contradict the limit.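

Compound 4 gives only a limit in this assay, as do compound 2 and compound 3, so neither step to compound 4 can be read. The compounds shown leave open how much of any compound the effect needs, and whether either change matters at all.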